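The source may report more compounds than this note shows. Statements on the series, on what has been measured and on what is new or still open speak of the compounds shown alone.

Measured so far:
Compound 1, `CN1CCN(c2ccc(C3=NN(S(C)(=O)=O)C(c4ccc(N(C)C)cc4)C3)cc2)CC1`: -1.3%
Compound 2, `Cc1ccc(S(=O)(=O)N2N=C(c3ccc(-n4cncn4)cc3)CC2c2ccc(N(C)C)cc2)cc1`: 20%
Compound 3, `C=C(C)C(=O)N1N=C(c2ccc(-n3ccnc3)cc2)CC1c1ccc(N(C)C)cc1`: -3.7%

Of the compounds shown here, three have been tested in a functional assay on NCI-H1975 cells (Homo sapiens) for inhibition, read by sulforhodamine B assay, tested at 10 uM; a higher number here means more inhibition at the concentration tested (going by the name of the read-out), a lower number less inhibition. Compound 1 gives -1.3%, compound 2 gives 20%, and compound 3 gives -3.7%. Compound 3 has the lowest of the three numbers; compound 1 lies within the usual scatter of it, so the two cannot be told apart, while compound 2 sits higher by more than the scatter.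

Compound 4, `CN(C)c1ccc(C2CC(c3ccc(-n4ccnc4)cc3)=NN2S(C)(=O)=O)cc1`, has not yet been measured. Compared with compound 3 it differs in one place: methylsulfonyl in place of (1-methylethenyl)carbonyl on an amine nitrogen in a ring. For the measured compounds named here, no measured pair shows this exact change, so its effect has to be guessed from what is at hand. Compound 1 also carries a methylsulfonyl on an amine nitrogen in a ring, and in this assay compound 1 gives -1.3%, a number that does not stand apart from compound 3. The step is therefore expected to be small, a number 6.7 percentage points higher from compound 3 to compound 4 (within the scatter), and not beyond the scatter. Compound 4 is estimated at 3%, with a range from -10% to 18%.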

Compound 4, a percentage reported as inhibition, at one concentration (the size of the read-out at that concentration, not a potency): -3.8%
The estimate for compound 4 lay 6.8 percentage points above the measured number; the measured number falls inside the stated range.
By their numbers in this assay, from the lowest: compounds 4, 3 and 1 (each within the scatter of the next); then compound 2.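

In this assay methylsulfonyl in place of (1-methylethenyl)carbonyl on an amine nitrogen in a ring gives a number 0.1 percentage points lower from compound 3 to compound 4 (within the scatter) and so, now read directly on a matched pair, the two groups cannot be told apart at this position. On an aromatic carbon, 1H-imidazol-1-yl in place of 4-methylpiperazin-1-yl gives a number 2.5 percentage points lower from compound 1 to compound 4 (within the scatter) and so this exchange cannot be told apart either, with methylsulfonyl kept on the ring nitrogen. Nothing at hand gives a reason for either result.

Compound 2 differs from compound 4 in more than one place, so its higher number cannot be credited to any single group. As far as these compounds go, whether a plain acetyl or a chain ending in a carboxylic acid on the same ring nitrogen would read differently remains open.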